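Pyrazoline series, phenylpyridazine cores: antiproliferative notes

A few compounds are considered here, and "the series" means these few. Any claim that something is new, unique, unknown or untested is made for them only; others in the source may bear on it.

Measured compounds:
- compound 1, `Clc1ccc(C2=NN(c3ccc(-c4ccccc4)nn3)C(c3ccccc3)C2)cc1`, 10000 nM
- compound 2, `Clc1ccc(C2=NN(c3ccc(-c4ccccc4)nn3)C(c3ccc(Cl)cc3)C2)cc1`, 8800 nM
- compound 3, `COc1ccc(C2CC(c3ccc(Cl)cc3)=NN2c2ccc(-c3ccccc3)nn2)cc1`, 100000 nM

All three were run in a functional assay on MCF7 cells (Homo sapiens) for antiproliferative activity, read by MTT assay, with a stated time of 24 h; a lower number here means a stronger inhibitor, a higher number a weaker inhibitor. The cores of compound 1 and compound 2 differ by hydrogen in place of chloro on an aromatic carbon, and that difference hardly moved the read-out: a 1.1-fold lower number from compound 1 to compound 2 (0.06 log units; within the scatter). The change of interest is methoxy in place of chloro on an aromatic carbon, which gave an 11-fold higher number from compound 2 to compound 3 (1.06 log units; beyond the scatter). The unmeasured compound 4, `COc1ccc(C2=NN(c3ccc(-c4ccccc4)nn3)C(c3ccccc3)C2)cc1`, carries the same change made on compound 1: methoxy in place of chloro on an aromatic carbon. The two place descriptions agree word for word, so this is taken as the same change, not merely the same kind. Going by the values given here, with the only precedent being the step from compound 2 to compound 3, and the core difference between compound 1 and compound 2 leaving the read-out nearly unchanged, a weakening of similar size is expected for compound 4, namely an 8.0-fold higher number from compound 1 to compound 4 (0.90 log units; beyond the scatter). Compound 4 is therefore estimated at 80000 nM, with a plausible span from 25000 nM to 250000 nM, the uncertainty resting on a single precedent.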

Compound 4, half-maximal inhibitory concentration: > 100000 nM
Compound 4 was reported as a limit; the forecaster's own chance of this, stated with the estimate: 25%; at least 1.2-fold (0.09 log units) between middle value and limit.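

The result for compound 4 in this assay is a limit and not a number: the limit of > 100000 nM in this assay, at which 1 of the 4 values shown sits.

Going from 4-chlorophenyl to 4-methoxyphenyl on the core of compound 1 gives an at least 10-fold higher number from compound 1 to compound 4 (1.00 log units; beyond the scatter) and so weakens the read-out beyond the scatter on this core as well, which means the direction of the change carries over from one core to the other: the same change on two cores in this assay, an 11-fold higher number (1.06 log units; beyond the scatter) from compound 2 to compound 3 and an at least 10-fold higher number (1.00 log units; beyond the scatter) from compound 1 to compound 4; the limit leaves it open whether they differ.

The size of the step on the core of compound 1 stays unfixed, so equal sizes on the two cores are neither shown nor ruled out, and a single pair of cores sets no rule for the wider series.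

The compounds shown leave open how an amine, a carboxylic acid or a longer alkoxy chain would read in place of the methoxy group on these cores. Also open, going by these compounds, is whether the loss seen with methoxy would hold in any read-out other than this assay.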